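Opening the ring of compound 1

This account rests on a few compounds, and the source may have more. Where it says the series, first, only, none or still open, it means among the compounds named here.

compound 1 `O=C(CCCCC1CCSS1)Nc1cccc(C(F)(F)F)c1`: 5.99%
compound 2 `O=C(CCCCC1CCSS1)Nc1ccc([N+](=O)[O-])c(C(F)(F)F)c1`: "not active" (no number reported)
compound 3 `O=C(CCCCC1CCSS1)Nc1ccc(Br)cn1`: 29.6%

All three compounds were tested in a functional assay on HO8910 cells (Homo sapiens) for inhibition, read by MTT assay, with a stated time of 24 h, tested at 10 ug/mL; a higher number here means more inhibition of growth at the concentration tested, a lower number less inhibition of growth. For the measured compounds named here, only two gave a number. Compound 1, at 5.99%, holds the lower of these, and compound 3, at 29.6%, lies above it by more than the usual scatter. Compound 2 is recorded as "not active" (no number reported) and cannot be ranked against them.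

Compound 4 `O=C(CCCCC(S)CCS)Nc1cccc(C(F)(F)F)c1` keeps the rest of compound 1 but opens its sulfur-containing ring: a group of 5 heavy atoms (3 carbon, 2 sulfur; no ring) in place of a group of 5 heavy atoms (3 carbon, 2 sulfur; one five-membered non-aromatic ring with 2 hetero atoms), on a saturated chain carbon, four bonds along the chain from a carbonyl carbon. The five-membered non-aromatic ring gives way to 1,3-disulfanylpropyl, which has no ring. Going by the values given here, no measured pair shows this kind of change, so the data offer no direct guide to its size. The expected step is a number 6 percentage points higher from compound 1 to compound 4 (within the scatter), leaning slightly upward but not beyond the scatter. The uncertainty is wide, and more room is expected above compound 1 than below it, since compound 1 at 5.99% already sits low. For compound 4 the estimated value is 12%, with an expected range from 0% to 35%.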

Compound 4, percent growth inhibition at one concentration: 8.86%
For compound 4 the middle estimate is 3.1 percentage points above the measured one; low and high end bracket the measured number.
By their numbers in this assay, from the lowest: compounds 1 and 4 (each within the scatter of the next); then compound 3.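

For the compounds shown here, compound 4 gives the first measured step for a change on a saturated chain carbon, four bonds along the chain from a carbonyl carbon: in this assay, opening the ring gives a number 2.9 percentage points higher from compound 1 to compound 4 (within the scatter) and so does not separate the two compounds. The five-membered non-aromatic ring, with 0 hydrogen-bond donors, and 1,3-disulfanylpropyl, with 2, therefore read alike at the single concentration tested. No measurement shown here accounts for this result.

On these data alone, it remains open whether a carboxylic acid or an amine in this place, or a longer chain leading to the carbonyl, would move the number beyond the scatter. As far as these compounds go, it is also open whether the same ring opening would leave compound 3, at 29.6%, equally unchanged.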